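Moving the Chlorine in Compound 1

A few compounds are considered here, and "the series" means these few. Any claim that something is new, unique, unknown or untested is made for them only; others in the source may bear on it.

compound 1 `Oc1ccc(-c2cc(-c3ccc(Cl)cc3)nc(-c3ccsc3)c2)cc1`: 6940 nM
compound 2 `Oc1ccc(-c2cc(-c3ccccc3)nc(-c3ccc(Cl)cc3)c2)cc1`: 7270 nM
compound 3 `Oc1ccc(-c2cc(-c3ccc(Cl)cc3)nc(-c3ccccn3)c2)cc1`: 22500 nM

These three values come from a functional assay on DU-145 cells (Homo sapiens) for cytotoxicity, read by CCK-8 assay and cell counting, with a stated time of 2 days; a lower number here means a stronger inhibitor, a higher number a weaker inhibitor. Compound 1 and compound 2 cannot be told apart, as the swap of thiophen-3-yl for phenyl gives a 1.0-fold higher number from compound 1 to compound 2 (0.02 log units; within the scatter). Compound 3 stands clearly apart from both, with pyridin-2-yl giving a 3.2-fold higher number from compound 1 to compound 3 (0.51 log units; beyond the scatter) and a 3.1-fold higher number from compound 2 to compound 3 (0.49 log units; beyond the scatter).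

Compound 4 `Oc1ccc(-c2cc(-c3ccsc3)nc(-c3cccc(Cl)c3)c2)cc1` has not yet been measured. It has the same atoms as compound 1, joined differently: 3-chlorophenyl in place of 4-chlorophenyl on an aromatic carbon. Among the compounds with values here, all three measured compounds carry 4-chlorophenyl, so no measured step tests this change directly. The nearest guide is how far swaps of a neighbouring ring group moved the number, and the largest of those, a 3.2-fold higher number from compound 1 to compound 3 (0.51 log units; beyond the scatter), was only modest. A small step is therefore expected in this assay, with no firm direction and probably none beyond the scatter. The expected step is a 1.2-fold higher number from compound 1 to compound 4 (0.06 log units; within the scatter). For compound 4 the estimated value is 8000 nM, with an expected range of 3500 nM to 18000 nM.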

Compound 4, half-maximal inhibitory concentration: 6220 nM
Estimate against measurement, compound 4: 1.3-fold (0.11 log units) above; measured number inside the range.
By their numbers in this assay, from the lowest: compounds 4, 1 and 2 (each within the scatter of the next); then compound 3.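

Within the data shown here, the earlier compounds all carried 4-chlorophenyl, so compound 4 is the first test of where the chlorine sits on this ring. In this assay, 3-chlorophenyl in place of 4-chlorophenyl gives a 1.1-fold lower number from compound 1 to compound 4 (0.05 log units; within the scatter), so the two arrangements of the same atoms cannot be told apart on the aromatic carbon next to the ring nitrogen. Nothing measured here explains this result.

This single pair covers only a chlorine at these two ring places, with thiophen-3-yl as the neighbouring group, so it cannot show whether the same holds alongside phenyl or pyridin-2-yl. Nor does it show what a different group on this ring, such as an amine or a carboxylic acid, would do to the number.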